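Swapping a Dibromophenyl Amide for a Methyl-Isoxazole

The compounds below may be only part of what the source reports. "The series", "measured", "known", "first", "only" and "open" are said of these compounds alone.

Compound 1, with the structure `COc1ccc(-n2c(SC(C)C(=O)Nc3cc(Br)ccc3Br)nc3ccccc32)cc1`, has no result in an ADME assay on Vero cells (Chlorocebus sabaeus) for cytotoxicity, read by MTT assay, with a stated time of 24 h; a higher number here means that more compound is tolerated, a lower number that less compound is tolerated: for compound 1 the entry reads "not determined" (no result reported), so there is no number to say where it stands. A close relative, compound 2 with the structure `CCOc1ccc(-n2c(SC(C)C(=O)Nc3ncc(Cl)cc3Cl)nc3ccccc32)cc1`, gives 18500 nM in this assay, which gives a rough idea of the level at which this family of compounds starts to harm the cells.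

Compound 3, with the structure `COc1ccc(-n2c(SC(C)C(=O)Nc3cc(C)no3)nc3ccccc32)cc1`, is derived from compound 1 by a single change: 3-methyl-1,2-oxazol-5-yl in place of 2,5-dibromophenyl on an amide-type nitrogen. The leaving group is a bromine-bearing benzene ring; the entering group is a small ring carrying nitrogen and oxygen. For the measured compounds named here, no measured pair shows how such a change moves the readout here, so no direction can be read from the data, and a modest shift either way, or none beyond the scatter, is the honest expectation.

On that basis compound 3 is expected to reach about 30000 nM in this assay, with an estimated range from 8000 nM to 100000 nM.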

Compound 3, half-maximal cytotoxic concentration: > 75000 nM
Compound 3: a limit, no number; the forecaster's own chance of this, stated with the estimate: 30%; at least 2.5-fold (0.39 log units) between middle value and limit.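

No step can be read between compound 1 and compound 3. In this assay compound 3 gives > 75000 nM as a limit and not a number. The compounds shown leave open how far replacing 2,5-dibromophenyl with 3-methyl-1,2-oxazol-5-yl shifts what the cells tolerate.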